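Aryl exchange on compound 2: clearance outlook

This account rests on a few compounds, and the source may have more. Where it says the series, first, only, none or still open, it means among the compounds named here.

In an in vitro ADME assay on microsomes from liver (Homo sapiens) for metabolic stability, with a stated time of 15 min (on this read-out higher numbers stand for fast clearance and lower numbers for slow clearance), compound 1 (`CCc1nn2c(-c3c(C)cc(C)cc3OC)cccc2c1N(CC1CC1)CC1CCCO1`) gives 1230 mL.min-1.g-1 and compound 2 (`CCc1nn2c(-c3c(C)cc(C)cc3OC)cccc2c1N(CC1CCOCC1)CC1CC1`) gives 450 mL.min-1.g-1, the lower of the two numbers. Compound 3 (`CCc1nn2c(-c3c(OC)cccc3OC)cccc2c1N(CC1CCOCC1)CC1CC1`) has no value yet. It carries 2,6-dimethoxyphenyl in place of 2-methoxy-4,6-dimethylphenyl on an aromatic carbon of a six-membered aromatic ring with 1 nitrogen, part of a fused or bridged system of two rings (2,6-dimethoxyphenyl in place of 2-methoxy-4,6-dimethylphenyl on an aromatic carbon).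

Among the compounds with values here, no measured step touches this group. Within the data shown here, the only step available is a 2.7-fold lower number from compound 1 to compound 2 (0.44 log units; beyond the scatter), with oxan-4-yl in place of oxolan-2-yl on a saturated chain carbon bound to a nitrogen on an aromatic ring. It is modest and beyond the scatter, but it lies at another place on the molecule, so it serves only as a rough gauge of size. The data fix no direction for the aryl exchange, and no change beyond the scatter is expected in this assay. The expected step, with a slight lean to a lower number, is a 1.3-fold lower number from compound 2 to compound 3 (0.11 log units; within the scatter). For compound 3 the estimated value is 350 mL.min-1.g-1, with an expected range of 150 mL.min-1.g-1 to 800 mL.min-1.g-1.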

Compound 3, intrinsic clearance in microsomes: 740 mL.min-1.g-1
Compound 3: the middle estimate sits 2.1-fold (0.33 log units) below what was measured; the measured number falls inside the stated range.
By their numbers in this assay, from the lowest: compounds 2, 3 and 1 (each within the scatter of the next, the first and the last beyond it).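

Working notes on the aryl position, on the aromatic carbon next to the ring nitrogen: in this assay, the only step shown here, 2,6-dimethoxyphenyl in place of 2-methoxy-4,6-dimethylphenyl, is a 1.6-fold higher number from compound 2 to compound 3 (0.22 log units; within the scatter), so the read-out does not separate these two aryl groups. The exchange keeps 10 heavy atoms and moves from 1 hydrogen-bond acceptor to 2 without a step beyond the scatter, whereas the exchange on the saturated chain, a 2.7-fold lower number from compound 1 to compound 2 (0.44 log units; beyond the scatter), does lie beyond it. Nothing available bears on the cause of either reading.

The compounds shown leave open how an aryl group carrying a nitrile, a fluorine or a carboxylic acid would read at this position, as only two aryl groups appear here. They also leave open whether the exchange to 2,6-dimethoxyphenyl would read the same with oxolan-2-yl on the saturated chain as it does with oxan-4-yl, and whether a larger change at the aryl position could match the size of the step seen on that chain.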